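A few compounds are considered here, and "the series" means these few. Any claim that something is new, unique, unknown or untested is made for them only; others in the source may bear on it.

Four compounds share one core, a fused two-ring system, and differ mainly in the group attached to an aromatic carbon of a five-membered aromatic ring with two nitrogen and one sulfur. Compound 1 `CCSc1nn2cc(-c3cc4ccccc4o3)nc2s1` carries an ethylthio group, and in an assay for antagonist activity at proteinase-activated receptor 4 (Homo sapiens), with stated times of 5 min, 50 s and 15 min, in the presence of a further agent that is not named here (on this read-out lower numbers stand for stronger inhibition and higher numbers for weaker inhibition), compound 1 gives "not determined" (no result reported). Compound 2 `CS(=O)(=O)c1nn2cc(-c3cc4ccccc4o3)nc2s1` carries a methylsulfonyl group. In this assay compound 2 gives > 30000 nM, which is a limit of the assay and not a number. Compound 3 `COc1nn2cc(-c3cc4c(OC)ccc(OC)c4o3)nc2s1` carries a methoxy group, with further methoxy groups elsewhere on its core, and in this assay compound 3 gives 2100 nM. Among the numbers shown, compound 2 stands at the weak end: it is the one compound sitting at the limit of > 30000 nM in this assay, at which 1 of the 3 values shown sits, while compound 3 is the only compound with a measured number.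

Compound 4 `CCOc1nn2cc(-c3cc4ccccc4o3)nc2s1` has not yet been tested. It differs from compound 2 in one place: ethoxy in place of methylsulfonyl on an aromatic carbon. No step between measured compounds is shown for this change, so the expectation rests on the resemblance between the ethoxy of compound 4 and the methoxy of compound 3, whose value 2100 nM is a number rather than a limit. Compound 4 is therefore expected to gain in this assay, with an estimated step of an at least 7.5-fold lower number from compound 2 to compound 4 (0.87 log units; beyond the scatter) away from the limit. Compound 4 is estimated at 4000 nM, between 800 nM and 25000 nM.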

Compound 4, half-maximal inhibitory concentration: 2100 nM
Compound 4: middle estimate off by 1.9-fold (0.28 log units), on the high side, within the range that was stated.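

Going by these compounds alone, this is the only pair here that differs in one place and has a result for both members, so it shows that the group on this aromatic carbon can by itself change the outcome in this assay: ethoxy in place of methylsulfonyl gives an at least 14-fold lower number from compound 2 to compound 4 (1.15 log units; beyond the scatter). That size is only a lower bound, because compound 2 sits at a limit of the assay rather than at a number: the limit of > 30000 nM in this assay, at which 1 of the 4 values shown sits.

The change also replaces a group with 2 hydrogen-bond acceptors and 2 double bonds outside aromatic rings by one with 1 hydrogen-bond acceptor and none of those double bonds, and this single pair cannot show which of these differences matters.

Compound 1 gives "not determined" (no result reported), so the step between the ethylthio and ethoxy groups cannot be read. Also open, from the compounds shown here alone, is how an amine or a longer chain such as butoxy on this carbon would compare with ethoxy, and whether ethoxy would hold its value with further methoxy groups on the core.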